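Adding a chloro group to compound 2

The compounds below may be only part of what the source reports. "The series", "measured", "known", "first", "only" and "open" are said of these compounds alone.

Compound 1 `N#Cc1c(-c2nnc(O)c3nn(-c4ccc(Cl)cc4)cc23)nn(-c2ccccc2)c1-c1ccccc1` gives > 100000 nM (a limit of the assay)
Compound 2 `N#Cc1c(-c2nnc(-c3ccccc3)c3nn(-c4ccccc4)cc23)nn(-c2ccccc2)c1-c1ccccc1` gives 21800 nM

Going by the values given here, in a functional assay on BT-549 cells (Homo sapiens) for inhibition, read by sulforhodamine B assay, with a stated time of 48 h (on this read-out higher numbers stand for weaker inhibition of growth and lower numbers for stronger inhibition of growth), compound 2 gives the only actual number so far (21800 nM). The result for compound 1 is a limit of the assay. Compound 3 `N#Cc1c(-c2nnc(-c3ccccc3)c3nn(-c4ccc(Cl)cc4)cc23)nn(-c2ccccc2)c1-c1ccccc1` carries chloro in place of hydrogen on an aromatic carbon of compound 2, turning phenyl to 4-chlorophenyl (chloro in place of hydrogen on an aromatic carbon). Among the compounds with values here, no measured pair shows this change alone, so starting from compound 2 at 21800 nM no shift beyond the scatter is expected in this assay. The expected change is a 1.1-fold lower number from compound 2 to compound 3 (0.04 log units; within the scatter), with no clear direction. For compound 3 the estimated value is 20000 nM (expected range 7000 nM to 60000 nM).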

Compound 3, concentration for 50% growth inhibition: 38800 nM
Estimate against measurement, compound 3: 1.9-fold (0.29 log units) below; measured number inside the range.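

In this assay, chloro in place of hydrogen on an aromatic carbon gives a 1.8-fold higher number from compound 2 to compound 3 (0.25 log units; within the scatter), so this change alone cannot be told apart from repeat-measurement scatter. Phenyl in place of hydroxy on an aromatic carbon gives an at least 2.5-fold lower number from compound 1 to compound 3 (0.41 log units; beyond the scatter), the only step here beyond the scatter, and its true size remains unknown. The result for compound 1 is a limit of the assay: the limit of > 100000 nM in this assay, at which 1 of the 3 values shown sits.

On these data alone, whether a methoxy group or an amine at the chloro position would shift the number remains open. So does the effect of an amine or a carboxylic acid where compound 3 carries that phenyl.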